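Chloro for fluoro on a quinolone ester against cell growth

A few compounds are considered here, and "the series" means these few. Any claim that something is new, unique, unknown or untested is made for them only; others in the source may bear on it.

Of the compounds shown here, three share a core and have been measured in an ADME assay on Raji cells (Homo sapiens) for cytotoxicity, read by luminescence, with a stated time of 72 h; on this read-out higher numbers stand for an effect only at larger amounts of compound and lower numbers for an effect already at smaller amounts. Compound 1, `CCOC(=O)c1c(-c2cccc(Oc3ccccc3)c2)[nH]c2cc(OC)c(Cl)cc2c1=O`, carries a phenoxy group and a chloro group. In this assay compound 1 gives > 21500 nM, which is a limit of the assay and not a number. Compound 2, `CCOC(=O)c1c(-c2cccc(Oc3ccccc3)c2)[nH]c2cc(OC)c(F)cc2c1=O`, differs from compound 1 by chloro in place of fluoro on an aromatic carbon. In this assay compound 2 gives > 21500 nM, again a limit of the assay rather than a number. The step that the two limits leave unreadable from compound 2 to compound 1 therefore cannot be sized. Compound 3, `CCOC(=O)c1c(-c2cccc(F)c2)[nH]c2cc(OC)c(F)cc2c1=O`, differs from compound 2 by fluoro in place of phenoxy on an aromatic carbon. In this assay compound 3 gives > 21500 nM, which is also a limit of the assay. The step that the two limits leave unreadable from compound 2 to compound 3 likewise cannot be sized, because of the limit of > 21500 nM in this assay, at which 3 of the 3 values shown sit.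

Compound 4, `CCOC(=O)c1c(-c2cccc(Cl)c2)[nH]c2cc(OC)c(F)cc2c1=O`, has not yet been measured. It differs from compound 3 by chloro in place of fluoro on an aromatic carbon. Among the compounds with values here, this is the same kind of change as the one from compound 2 to compound 1, but the place is not the same: there it sits on a ring that is part of a fused or bridged system of two rings, ortho to a methoxy group, meta to a fused ring and para to a fused ring, whereas here it sits on a six-membered aromatic ring of carbon only, meta to a large group. Since the three measured compounds all sit at the limit, and because of the limit of > 21500 nM in this assay, at which 3 of the 3 values shown sit, the step from compound 3 to compound 4 is expected to be small, about a step that the limit leaves unreadable from compound 3 to compound 4. Compound 4 is therefore expected to give roughly 30000 nM in this assay, most likely again as a limit.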

Compound 4, half-maximal effective concentration: > 21500 nM
Compound 4: no number, only a limit; the forecaster's own chance of this, stated with the estimate: 85%; the middle value lies beyond the limit too.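

In this assay compound 4 gives > 21500 nM, which is a limit of the assay and not a number. Within the data shown here, no step from compound 3 or compound 2 to compound 4 can be read, because every value sits at the same limit: the limit of > 21500 nM in this assay, at which 4 of the 4 values shown sit. Left open is whether chloro in place of fluoro, or any other change among compound 1, compound 2, compound 3 and compound 4, alters the effect on these cells at all.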